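Amide heteroaryl exchange on the propyl-bearing core

The source may hold more compounds than are shown below. What is called first, only, known or untested is meant among the compounds shown, and "the series" means these compounds.

Compound 2 `CCC[C@@H](NC(=O)c1ccccn1)c1cnc(Nc2ccc(C)nc2)c(Cl)c1` sits in a functional assay on HEK293 cells for negative allosteric modulation of metabotropic glutamate receptor 5 (Homo sapiens), read by HTRF and inositol phosphate accumulation (a higher number here means a weaker inhibitor, a lower number a stronger inhibitor), at 27.8 nM. Within the data shown here, the only other measured member, compound 1 `COC[C@H](NC(=O)c1nccs1)c1cnc(Nc2ccc(C)nc2)c(Cl)c1`, gives 55.9 nM in this assay; the two values lie within the usual scatter of each other, so no order is read from them. Compound 3 `CCC[C@@H](NC(=O)c1cscn1)c1cnc(Nc2ccc(C)nc2)c(Cl)c1` carries 1,3-thiazol-4-yl in place of pyridin-2-yl on a carbonyl carbon. Among the measured compounds shown here, no measured pair shows this exchange, so the step from compound 2 is expected to stay small, at most marginally towards a higher number, estimated as a 1.4-fold higher number from compound 2 to compound 3 (0.16 log units; within the scatter). Compound 3 is therefore expected near 40 nM, within 15 nM to 110 nM.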

Compound 3, half-maximal inhibitory concentration: 31.2 nM
For compound 3 the middle estimate is 1.3-fold (0.11 log units) above the measured one; measured number inside the range.
By their numbers in this assay, from the lowest: compounds 2, 3 and 1 (each within the scatter of the next).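

In this assay, among these compounds, exchanging pyridin-2-yl for 1,3-thiazol-4-yl on the carbonyl carbon gives a 1.1-fold higher number from compound 2 to compound 3 (0.05 log units; within the scatter), the only single-place comparison so far. This position therefore accepts a five-membered aromatic ring with 2 hetero atoms in place of a six-membered one without a change beyond the scatter. No supporting data bear on this result.

From the compounds shown here alone, whether a plain phenyl ring, a cyclohexyl ring or a dimethylamino group on the same carbonyl carbon would hold the value remains open. Going by these compounds, the role of the propyl chain also remains open, as compound 1 differs from compound 3 in more than one place.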